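The source may report more compounds than this note shows. Statements on the series, on what has been measured and on what is new or still open speak of the compounds shown alone.

Working notes on the series, read in a functional assay on L1210 cells (Mus musculus) for cytotoxicity, with a stated time of 48 h; on this read-out higher numbers stand for weaker inhibition and lower numbers for stronger inhibition.

Compound 3 `C=C1CC(CC)OC1=O` gives 6000 nM in this assay, the lowest of the two single numbers on hand. Its nearest neighbour is compound 2 `C=C1CC(C)OC1=O`, which gives 32500 nM in this assay; the step of a 5.4-fold lower number from compound 2 to compound 3 (0.73 log units; beyond the scatter) is beyond the scatter. Compound 1 `C=C1C(=O)OC(c2ccc(Br)cc2)C1C` stands apart with two entries, 7500 nM; 1550 nM (2 entries) in this assay, and these repeats the several entries of compound 1 in this assay, 7500 nM; 1550 nM (2 entries) show how far single readings of this kind can drift.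

Compound 4 `C=C1CC(CCCCC)OC1=O` differs from compound 3 by propyl in place of hydrogen on a saturated chain carbon, two bonds along the chain from a saturated ring carbon. Within the data shown here, the only measured step that bears on this change is a 5.4-fold lower number from compound 2 to compound 3 (0.73 log units; beyond the scatter), a modest gain from lengthening the chain on the saturated ring carbon; the step to compound 4 extends the same chain further, though at a point further from the ring. Among the measured compounds shown here, a further lowering of the number is therefore expected, of about the same size, although no measured step fixes how far chain length can be pushed.

For compound 4 the estimated step is a 4.0-fold lower number from compound 3 to compound 4 (0.60 log units; beyond the scatter). Compound 4 is expected to give 1500 nM in this assay, with a plausible range from 400 nM to 6000 nM.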

Compound 4, half-maximal inhibitory concentration: 20000 nM
Estimate against measurement, compound 4: 13-fold (1.12 log units) below, and the stated range ends below it.
By their numbers in this assay, from the lowest: compound 3; then compounds 4 and 2 (each within the scatter of the next).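

Propyl in place of hydrogen on a saturated chain carbon, two bonds along the chain from a saturated ring carbon, runs against the earlier step in this assay: a 3.3-fold higher number from compound 3 to compound 4 (0.52 log units; beyond the scatter), where before there was a 5.4-fold lower number from compound 2 to compound 3 (0.73 log units; beyond the scatter). The remaining comparison reads a 1.6-fold lower number from compound 2 to compound 4 (0.21 log units; within the scatter), so among these three compounds the lower number stands with compound 3 alone and does not follow chain length in one direction. Single readings of this kind can drift, so the size of each step is best held loosely: the several entries of compound 1 in this assay, 7500 nM; 1550 nM (2 entries)

As far as these compounds go, what a chain of intermediate length or a longer chain gives at this place stays open. Also open, from the compounds shown here alone, is how an amine or a carboxylic acid on the chain would read.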